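Swapping the thiophene for phenyl on a hydroxamic acid triazole

This account rests on a few compounds, and the source may have more. Where it says the series, first, only, none or still open, it means among the compounds named here.

Measured compounds:
compound 1 `O=C(NO)c1ccc(NCc2nc(-c3cccnc3)nn2-c2ccccc2)cc1` — 57.7%
compound 2 `CCc1ccc(-n2nc(-c3ccccc3)nc2CNc2ccc(C(=O)NO)cc2)cc1` — 38.3%
compound 3 `Cc1ccsc1-c1nc(CNc2ccc(C(=O)NO)cc2)n(-c2ccccc2)n1` — 72.1%

Of the compounds shown here, three sharing a hydroxamic acid core have been tested in an assay on Sf9 cells for inhibition of protein deacetylase HDAC6 (Homo sapiens), read by fluorescence, with a stated time of 40 min, tested at 100 nM; a higher number here means more inhibition at the concentration tested (going by the name of the read-out), a lower number less inhibition. Compound 3 stands highest of the three in this assay; compound 1 sits nearer to it, and the step of a number 14.4 percentage points higher from compound 1 to compound 3 (beyond the scatter) is beyond the scatter, while compound 2 lies furthest from compound 3.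

The next compound, compound 4 `O=C(NO)c1ccc(NCc2nc(-c3ccccc3)nn2-c2ccccc2)cc1`, is compound 3 with one change: phenyl in place of 3-methylthiophen-2-yl on an aromatic carbon. For the measured compounds named here, the only measured step that touches this position is the one from compound 1 to compound 3, and it was modest in size. Compound 2 also carries a phenyl on that carbon, but it differs from compound 4 elsewhere as well, so its value can only be noted, not used as a step. Since a change at this carbon has already moved the read-out beyond the scatter once, compound 4 is expected to fall below compound 3, with the step of a number 20.1 percentage points lower from compound 3 to compound 4 (beyond the scatter) expected to be of moderate size. Compound 4 is therefore estimated at 52%, with a range from 32% to 70% in this assay.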

Compound 4, a percentage reported as inhibition, at one concentration (the size of the read-out at that concentration, not a potency): 72.6%
The estimate for compound 4 lay 20.6 percentage points below the measured number; measured number above the stated range.
By their numbers in this assay, from the lowest: compound 2; then compound 1; then compounds 3 and 4 (each within the scatter of the next).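

In this assay, the carbon between two ring nitrogen atoms accepts phenyl and 3-methylthiophen-2-yl alike, with a step of a number 0.5 percentage points higher from compound 3 to compound 4 (within the scatter), while pyridin-3-yl now stands apart from both, since a number 14.9 percentage points higher from compound 1 to compound 4 (beyond the scatter) matches the earlier a number 14.4 percentage points higher from compound 1 to compound 3 (beyond the scatter). Compound 4 also gives the first reading at a second place in the molecule: hydrogen in place of ethyl on an aromatic carbon is a number 34.3 percentage points higher from compound 2 to compound 4 (beyond the scatter), the largest step among these compounds. Nothing available explains either finding.

The compounds shown leave open how an amine, a carboxylic acid or a saturated chain such as propyl would read on the carbon between two ring nitrogen atoms. They also leave open whether a methyl or a methoxy group in place of the ethyl would cost as much as the ethyl does.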